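The source may report more compounds than this note shows. Statements on the series, on what has been measured and on what is new or still open speak of the compounds shown alone.

- Compound 1 `Oc1ccc(Nc2nc(-c3cccc(F)c3)nc3ccc(F)cc23)cc1`: > 50000 nM, a limit and not a number
- Compound 2 `Nc1ccccc1Nc1nc(-c2cccc(F)c2)nc2ccc(F)cc12`: 47300 nM
- Compound 3 `Cc1ccc(Nc2nc(-c3cccc(F)c3)nc3ccc(F)cc23)cc1`: not yet measured

Going by the values given here, in a functional assay on U-937 cells (Homo sapiens) for cytotoxicity, read by MTT assay, with a stated time of 48 h (on this read-out lower numbers stand for stronger inhibition and higher numbers for weaker inhibition), compound 2 gives 47300 nM, the only true number so far. The reading for compound 1 is a limit. Compound 3 puts 4-methylphenyl in place of 2-aminophenyl on a nitrogen on an aromatic ring. Among the compounds with values here, one measured step bears on this, since it changes the group at the same place: an at least 1.0-fold lower number from compound 1 to compound 2 (0.02 log units; that floor lies within the scatter). That step stays within the scatter, and with one end at a limit it is thin evidence. No change beyond the scatter is therefore expected, and the estimated step is a 1.2-fold lower number from compound 2 to compound 3 (0.07 log units; within the scatter). For compound 3 the expected value is 40000 nM, with an estimated range from 15000 nM to 60000 nM.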

Compound 3, half-maximal inhibitory concentration: > 50000 nM
Compound 3: only a limit was reported (the forecaster's own chance of this, stated with the estimate: 45%); middle value at least 1.2-fold (0.09 log units) away from the limit.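

Putting 4-methylphenyl in place of 2-aminophenyl on a nitrogen on an aromatic ring gives, in this assay, an at least 1.0-fold higher number from compound 2 to compound 3 (0.02 log units; that floor lies within the scatter), so the reading shows no gain from this change. The entering group has no hydrogen-bond donor or acceptor, yet the result gives no sign of stronger inhibition than the group that has one of each. The step between the hydroxy and methyl compounds cannot be read, because both readings are limits and not numbers: the limit of > 50000 nM in this assay, at which 2 of the 3 values shown sit.

Still open, on these data alone, is how far compound 1 and compound 3 lie past that limit, which hides any real difference between them. Also open, as far as these compounds go, is whether a carboxylic acid, an aliphatic amine or a longer chain at this place would give a number clearly lower than these.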